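Aryl halogen variation on the shared core, compound 4 outlook

This account rests on a few compounds, and the source may have more. Where it says the series, first, only, none or still open, it means among the compounds named here.

Measured compounds:
- Compound 1 `COc1cc(NC(=O)c2cncc(N3CC4CC(C3)N4)c2)cc(OC)c1` gives 0.985 nM in an assay on membranes from Cerebral cortex for displacement of a labelled ligand from Neuronal acetylcholine receptor; alpha4/beta2 (Rattus norvegicus); on this read-out lower numbers stand for stronger inhibition and higher numbers for weaker inhibition.
- Compound 2 `O=C(Nc1ccc(I)cc1)c1cncc(N2CC3CC(C2)N3)c1` gives 0.366 nM in this assay.
- Compound 3 `O=C(Nc1ccc(F)cc1)c1cncc(N2CC3CC(C2)N3)c1` gives 0.01 nM in this assay.

Compound 3 has the lowest number of the three; its nearest neighbour is compound 2, at a step of a 37-fold lower number from compound 2 to compound 3 (1.56 log units; beyond the scatter), and compound 1 stands further off still. Going by the values given here, the only measured step that bears on an aryl halogen swap is a 37-fold lower number from compound 2 to compound 3 (1.56 log units; beyond the scatter), which is large and beyond the scatter.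

Compound 4 `O=C(Nc1cccc(Cl)c1)c1cncc(N2CC3CC(C2)N3)c1` differs from compound 3 by 3-chlorophenyl in place of 4-fluorophenyl on an amide-type nitrogen. Among the compounds with values here, no measured compound carries chloro, and none carries a halogen on the 3-position, so the direction of this change has no direct precedent among the three values shown. Because compound 3 sits at 0.01 nM, well below compound 2 at 0.366 nM, a return toward the numbers of compounds 1 and 2 is taken as the more likely outcome.

For compound 4 the expected value in this assay is 0.12 nM, with a range from 0.02 nM to 0.8 nM; this estimate implies a step of a 12-fold higher number from compound 3 to compound 4 (1.08 log units; beyond the scatter).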

Compound 4, inhibition constant: 0.042 nM
Beside the measured number, compound 4's estimate is 2.9-fold (0.46 log units) above it; low and high end bracket the measured number.
By their numbers in this assay, from the lowest: compound 3; then compound 4; then compound 2; then compound 1.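

In this assay, a chloro group on the aryl ring at this amide-type nitrogen gives a 4.2-fold higher number from compound 3 to compound 4 (0.62 log units; beyond the scatter) and an 8.7-fold lower number from compound 2 to compound 4 (0.94 log units; beyond the scatter), so compound 4 falls between compound 3 and compound 2 with both steps beyond the scatter. Compound 4 changes both the halogen and its ring position relative to compound 3 and compound 2, so these two changes cannot be read apart. No measurement on hand accounts for either step.

On these data alone, whether the halogen or its ring position sets the size of these steps stays open, and a matched pair such as 3-fluorophenyl and 4-chlorophenyl would address that. As far as these compounds go, how an aminophenyl or a carboxyphenyl group, or a longer chain in place of the aryl ring, would read in this assay also remains open.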